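The compounds below may be only part of what the source reports. "The series", "measured", "known", "first", "only" and "open" are said of these compounds alone.

Of the compounds shown here, three have been tested in a functional assay on Z-138 cells (Homo sapiens) for inhibition, read by luminescence and CellTiter-Glo, with a stated time of 72 h; a higher number here means a weaker inhibitor, a lower number a stronger inhibitor. Compound 1 `C=CC(=O)Nc1ccc(Cn2nc(-c3ccc(Oc4ccccc4)cc3)cc2C(=O)O)cc1` gives > 60000 nM in this assay, which is a limit of the assay and not a number. Compound 3 `C=CC(=O)Nc1ccc(Cn2nc(-c3ccc(Oc4ccccc4)cc3)cc2C(=O)OCC)cc1` gives 12500 nM in this assay, and the change between the two shows as an at least 4.8-fold lower number from compound 1 to compound 3 (0.68 log units; beyond the scatter); one of the three values sits at the limit of > 60000 nM in this assay, at which 1 of the 3 values shown sits. Compound 2 `C/C=C/C(=O)Nc1cccc(Cn2nc(-c3ccc(Oc4ccccc4)cc3)cc2C(=O)O)c1` gives 24100 nM in this assay. Among the two actual numbers, compound 3 stands lowest, with compound 2 nearest and within the scatter, so the two cannot be told apart.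

Compound 4 `C=CC(=O)Nc1cccc(Cn2nc(-c3ccc(Oc4ccccc4)cc3)cc2C(=O)OCC)c1` has not yet been measured. It differs from compound 3 by 3-((vinylcarbonyl)amino)phenyl in place of 4-((vinylcarbonyl)amino)phenyl on a saturated chain carbon bound to an aromatic nitrogen. Among the compounds with values here, no measured step bears directly on this change: compound 1 and compound 2 differ at this place but also elsewhere, so their values show only that a limit and a number were found. With nothing pointing in either direction, no step beyond the scatter is expected in this assay, and the expected step is a 1.3-fold lower number from compound 3 to compound 4 (0.10 log units; within the scatter). Compound 4 is therefore estimated to give about 10000 nM, within a range from 3000 nM to 35000 nM.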

Compound 4, half-maximal inhibitory concentration: 7800 nM
Compound 4: the middle estimate sits 1.3-fold (0.11 log units) above what was measured, within the range that was stated.
By their numbers in this assay, from the lowest: compounds 4, 3 and 2 (each within the scatter of the next, the first and the last beyond it). At a limit, above all of these: compound 1.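

In this assay, 3-((vinylcarbonyl)amino)phenyl in place of 4-((vinylcarbonyl)amino)phenyl on a saturated chain carbon bound to an aromatic nitrogen gives a 1.6-fold lower number from compound 3 to compound 4 (0.20 log units; within the scatter), so with the ethyl ester held fixed, the two groups cannot be told apart in this assay. Within the data shown here, this is the first direct reading of this change, as compound 1 and compound 2 differ at this place and also in the chain on the amide, while the value of compound 1 is a limit of the assay and not a number: the limit of > 60000 nM in this assay, at which 1 of the 4 values shown sits. Nothing measured here gives a reason why the two groups read alike.

As far as these compounds go, it remains open whether the vinylcarbonyl group matters at all in either group, which an amine or a saturated propanoyl amide at the same place on the ring would test. Among these compounds, also open is whether an at least 4.8-fold lower number from compound 1 to compound 3 (0.68 log units; beyond the scatter), the only step seen so far at the ester, extends to a methyl ester or a longer chain on that oxygen, and whether it holds for 3-((vinylcarbonyl)amino)phenyl.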